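The compounds below may be only part of what the source reports. "The series", "measured", "known", "first", "only" and "open" are said of these compounds alone.

Measured compounds:
compound 1 `CCS(=O)(=O)Nc1cc(-c2ccc3ncnc(Nc4ccc(F)cc4)c3c2)cnc1OC` gives 1470 nM in a functional assay on SK-HEP1 cells (Homo sapiens) for cytotoxicity, read by sulforhodamine B assay, with a stated time of 72 h; on this read-out lower numbers stand for stronger inhibition and higher numbers for weaker inhibition
compound 2 `CCS(=O)(=O)Nc1cc(-c2ccc3ncnc(Nc4ccc(OC(F)(F)F)cc4)c3c2)cnc1OC` gives 6140 nM in this assay
compound 3 `CCS(=O)(=O)Nc1cc(-c2ccc3ncnc(Nc4ccc(OC)c(Cl)c4)c3c2)cnc1OC` gives 2810 nM in this assay

Compound 3 stands second highest of the three numbers. Its nearest neighbour is compound 1, with a 1.9-fold higher number from compound 1 to compound 3 (0.28 log units; within the scatter); the furthest is compound 2, with a 2.2-fold lower number from compound 2 to compound 3 (0.34 log units; beyond the scatter). The remaining measured step, a 4.2-fold higher number from compound 1 to compound 2 (0.62 log units; beyond the scatter), is the largest change among the three.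

Compound 4 `CCS(=O)(=O)Nc1cc(-c2ccc3ncnc(Nc4ccc(F)nc4)c3c2)cnc1OC` has not yet been measured. The change from compound 3 is 6-fluoropyridin-3-yl in place of 3-chloro-4-methoxyphenyl on a nitrogen on an aromatic ring. All three measured steps concern the same place on the shared core, the aryl group on that nitrogen, and together they span a modest range. Going by the values given here, the 6-fluoropyridin-3-yl group has no measured counterpart here; the closest comparison is compound 1, whose 4-fluorophenyl group also carries a single fluorine and whose value, 1470 nM, sits close to that of compound 3. Nothing in the series shows what exchanging a ring carbon for a ring nitrogen does in this assay, so only a small step is anticipated, in either direction or none beyond the scatter.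

For compound 4 the expected value in this assay is 2200 nM, with a range from 800 nM to 6000 nM. The step this estimate implies is a 1.3-fold lower number from compound 3 to compound 4 (0.11 log units; within the scatter), expected to lie within the scatter.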

Compound 4, half-maximal inhibitory concentration: 5240 nM
Compound 4: middle estimate off by 2.4-fold (0.38 log units), on the low side; measured number inside the range.
By their numbers in this assay, from the lowest: compounds 1, 3, 4 and 2 (each within the scatter of the next, the first and the last beyond it).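

In this assay, going by these compounds alone, the one comparison that isolates a ring nitrogen at this place, with the ring fluorine kept, is 6-fluoropyridin-3-yl in place of 4-fluorophenyl, and it gives a 3.6-fold higher number from compound 1 to compound 4 (0.55 log units; beyond the scatter), a weaker result and the first sign that this exchange is not neutral on the shared core. The other two steps, a 1.9-fold higher number from compound 3 to compound 4 (0.27 log units; within the scatter) and a 1.2-fold lower number from compound 2 to compound 4 (0.07 log units; within the scatter), leave the 6-fluoropyridin-3-yl group unresolved from both 3-chloro-4-methoxyphenyl and 4-(trifluoromethoxy)phenyl, so among the groups on this nitrogen it stands apart only from 4-fluorophenyl. Nothing available here explains the step from the 4-fluorophenyl group to the 6-fluoropyridin-3-yl group.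

The compounds shown leave open whether the weaker result follows the ring nitrogen itself or depends on the fluorine it accompanies, a question that a plain pyridin-3-yl, a 6-methoxypyridin-3-yl or a 6-aminopyridin-3-yl group on the same nitrogen would address. They also leave open whether the step from the 4-fluorophenyl group holds on any cell line other than the one used in this assay.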